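A few compounds are considered here, and "the series" means these few. Any claim that something is new, unique, unknown or untested is made for them only; others in the source may bear on it.

Compound 1 `Cc1cccc(NC(=O)N[C@H](C)c2ccccc2)c1` gives 100% in an ADME assay on the whole organism with Oryza sativa as the target, tested at 0.1 uM; on this read-out higher numbers stand for a weaker effect at the one concentration tested and lower numbers for a stronger effect.
Compound 2 `Cc1cccc(NC(=O)N[C@@H](C)c2ccccc2)c1` gives 99% in this assay.
Compound 3 `CCCCCCCc1ccc(NC(=O)N[C@H](C)c2ccccc2)cc1` gives 100% in this assay.

Compound 1 stands level with compound 3 at the digits shown, the two together the highest of the three numbers, and the gap to compound 2 is within the scatter. Among the compounds with values here, the only measured step between compounds that differ in one place is a number 1 percentage points lower from compound 1 to compound 2 (within the scatter), which is a step within the scatter and rests on (the fact that compounds 1 and 2 differ only in the configuration as drawn). All three measured numbers sit at the top of the scale in this assay.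

Compound 4 `C[C@@H](NC(=O)Nc1cccc(F)c1)c1ccccc1` differs from compound 1 in one place: fluoro in place of methyl on an aromatic carbon. Within the data shown here, no measured step tests a change of this kind, so the expectation for compound 4 can rest only on the measured numbers all lying close together near the top of the scale. The estimated step is a number 2 percentage points lower from compound 1 to compound 4 (within the scatter), expected to stay within the scatter. Compound 4 is therefore expected to give about 98% in this assay, with a range from 88% to 100%.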

Compound 4, a percentage reported as activity, at one concentration (the size of the read-out at that concentration, not a potency): 99%
Beside the measured number, compound 4's estimate is 1 percentage points below it, within the range that was stated.
By their numbers in this assay, from the lowest: compounds 2, 4, 1 and 3 (each within the scatter of the next).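

In this assay, fluoro in place of methyl on an aromatic carbon, meta to a large group, gives a number 1 percentage points lower from compound 1 to compound 4 (within the scatter). Within the data shown here, this is the first measured step that changes a substituent on this ring rather than the configuration as drawn, and it shows that this one exchange of a single heavy atom leaves the number within the scatter. Nothing measured here bears on why the number stays where it does.

On these data alone, it remains open whether a larger or different group at this position, such as an amine, a carboxylic acid or a longer chain, would move the number away from the top of the scale. As far as these compounds go, it is equally open whether any change to the shared core would give a stronger effect beyond the scatter in this assay.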